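Replacing one aromatic ring on compound 3

The compounds below may be only part of what the source reports. "The series", "measured", "known", "first", "only" and "open" are said of these compounds alone.

Among the measured compounds shown here, in an ADME assay on the whole organism (Mus musculus, strain BALB/c), read by LC-MS, with a stated time of 24 h, at a dose of 10 mg/kg by the oral route (on this read-out higher numbers stand for higher exposure at the dose given and lower numbers for lower exposure), compound 3 `O=S(=O)(Nc1nccs1)c1ccc2c(c1)OCC[C@@H]2c1ccc(C(F)(F)F)cc1-n1ccnn1` gives 3600 ng.h/mL as the lowest of the three numbers so far. Compound 2 `Cn1nccc1-c1cc(C(F)(F)F)ccc1[C@H]1CCOc2cc(S(=O)(=O)Nc3nccs3)ccc21` gives 7810 ng.h/mL and compound 1 `O=S(=O)(Nc1ncccn1)c1ccc2c(c1)OCC[C@@H]2c1ccc(C(F)(F)F)cc1-c1ccc(F)nc1` gives 90700 ng.h/mL at the top. Compound 4 `O=S(=O)(Nc1nccs1)c1ccc2c(c1)OCC[C@@H]2c1ccc(C(F)(F)F)cc1-c1ccc(F)nc1` keeps the core of compound 3 but carries 6-fluoropyridin-3-yl in place of 1H-1,2,3-triazol-1-yl on an aromatic carbon. For the measured compounds named here, the one measured step at this place, with 1H-1,2,3-triazol-1-yl entering for 1-methyl-1H-pyrazol-5-yl, is modest: a 2.2-fold lower number from compound 2 to compound 3 (0.34 log units; beyond the scatter) and it ends on the group that now leaves. Compound 1 already carries 6-fluoropyridin-3-yl and gives 90700 ng.h/mL here, yet it differs from compound 4 elsewhere, so its number only hints at a rise. A rise larger than that modest step is expected, estimated as a 4.4-fold higher number from compound 3 to compound 4 (0.65 log units; beyond the scatter) on this thin evidence. Compound 4 is estimated at 16000 ng.h/mL within an expected range of 5000 ng.h/mL to 60000 ng.h/mL for now.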

Compound 4, area under the concentration-time curve: 10200 ng.h/mL
The estimate for compound 4 lay 1.6-fold (0.20 log units) above the measured number; low and high end bracket the measured number.
By their numbers in this assay, from the lowest: compound 3; then compounds 2 and 4 (each within the scatter of the next); then compound 1.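

In this assay, the change on this aromatic carbon, ortho to a large group, now has a direct reading on one core, with a 2.8-fold higher number from compound 3 to compound 4 (0.45 log units; beyond the scatter) as 6-fluoropyridin-3-yl replaces 1H-1,2,3-triazol-1-yl. Set against 1-methyl-1H-pyrazol-5-yl, the same group shows no separation, with a 1.3-fold higher number from compound 2 to compound 4 (0.12 log units; within the scatter), so among these three groups only 1H-1,2,3-triazol-1-yl stands apart. With 6-fluoropyridin-3-yl held fixed, the bigger step lies at the sulfonamide nitrogen, where 1,3-thiazol-2-yl in place of pyrimidin-2-yl gives an 8.9-fold lower number from compound 1 to compound 4 (0.95 log units; beyond the scatter).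

Nothing available explains these differences in exposure. Still open, as far as these compounds go, are how an amine or a carboxylic acid on this aromatic carbon would compare, and whether pyrimidin-2-yl on the sulfonamide nitrogen would give a similar step alongside 1H-1,2,3-triazol-1-yl.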